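Methylating the Sulfonamide Nitrogen of a Bromo Anticonvulsant

A few compounds are considered here, and "the series" means these few. Any claim that something is new, unique, unknown or untested is made for them only; others in the source may bear on it.

Compound 2 `NS(=O)(=O)Cc1noc2ccc(Br)cc12` and compound 1 `NS(=O)(=O)Cc1noc2ccc(F)cc12` share one core and differ only at a single aromatic carbon. In a functional assay on the whole organism (strain STD-dd) with Mus musculus as the target, in the maximal electroshock model, with a stated time of 2 h (on this read-out lower numbers stand for an effect already at smaller amounts and higher numbers for an effect only at larger amounts of compound), compound 1 gives 15 mg/kg, and compound 2 gives 14 mg/kg. The step of a 1.1-fold lower number from compound 1 to compound 2 (0.03 log units; within the scatter) shows that the two halogens produce numbers within the scatter of each other, so neither compound can be called the more potent; compound 2 simply holds the lowest of the two numbers, with compound 1 standing close by.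

Compound 3 `CN(C)S(=O)(=O)Cc1noc2ccc(Br)cc12` is the unmeasured compound. It differs from compound 2 in one place: dimethylamino in place of amino on a sulfonyl sulfur. Going by the values given here, the only measured step concerns the halogen on the aromatic carbon and says nothing about the sulfonyl end of the molecule, so no measured step bears on this change. The expectation for compound 3 therefore rests on the structural change alone. In this assay compound 3 is expected to need a larger amount, giving an estimated 60 mg/kg with a range from 20 mg/kg to 300 mg/kg. This corresponds to an expected step of a 4.3-fold higher number from compound 2 to compound 3 (0.63 log units; beyond the scatter), with a real chance that only a limit is reported.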

Compound 3, dose for half-maximal effect: 45 mg/kg
Compound 3: middle estimate off by 1.3-fold (0.12 log units), on the high side, within the range that was stated.
By their numbers in this assay, from the lowest: compounds 2 and 1 (each within the scatter of the next); then compound 3.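

Until now, the only change shown was the halogen on the aromatic carbon, and it left the numbers within the scatter of each other, so the sulfonyl end is the first place here where a single change clearly moves the result. In this assay, dimethylamino in place of amino on a sulfonyl sulfur gives a 3.2-fold higher number from compound 2 to compound 3 (0.51 log units; beyond the scatter), so a larger amount of compound is needed, yet the read-out still yields a real number rather than a limit, and the effect survives the change. No measurement at hand gives a reason for this step.

This single pair cannot show whether the shift comes from replacing the hydrogens on the nitrogen as a whole or would already appear with methylamino, which might land nearer compound 2 or nearer compound 3. Also open, from the compounds shown here alone, are whether larger groups on the sulfonyl sulfur, such as diethylamino or morpholine, would raise the number further, and whether dimethylamino would produce a step of similar size on the fluoro compound, compound 1.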